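The source may report more compounds than this note shows. Statements on the series, on what has been measured and on what is new or still open speak of the compounds shown alone.

In a functional assay (Homo sapiens) for inhibition (on this read-out higher numbers stand for weaker inhibition and lower numbers for stronger inhibition), compound 1 (`CS(=O)(=O)c1ccc(CSc2nc(-c3ccc(F)cc3)c(-c3ccncc3)[nH]2)cc1`) gives 330 nM and compound 2 (`CSc1cccc(CSc2nc(-c3ccc(F)cc3)c(-c3ccncc3)[nH]2)c1`) gives 550 nM as its value, so the two stand within the scatter of each other. Compound 3 (`CS(=O)(=O)c1ccc(CSc2nc(-c3ccc(Br)cc3)c(-c3ccncc3)[nH]2)cc1`) differs from compound 1 by bromo in place of fluoro on an aromatic carbon. Going by the values given here, the one measured step (a 1.7-fold higher number from compound 1 to compound 2 (0.22 log units; within the scatter)) concerns another group and lies within the scatter. Among the compounds with values here, no measured step touches the 4-fluorophenyl group, so no step beyond the scatter is expected in this assay and no direction can be given. Compound 3 is estimated at 380 nM (range 130 nM to 1100 nM). That estimate means an expected step (a 1.2-fold higher number from compound 1 to compound 3 (0.06 log units; within the scatter)).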

Compound 3, half-maximal inhibitory concentration: 640 nM
For compound 3 the middle estimate is 1.7-fold (0.23 log units) below the measured one, within the range that was stated.
By their numbers in this assay, from the lowest: compounds 1, 2 and 3 (each within the scatter of the next).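

In this assay, going by these compounds alone, the 4-bromophenyl group of compound 3 gives the first measured change at the 4-fluorophenyl position, with a 1.9-fold higher number from compound 1 to compound 3 (0.29 log units; within the scatter) as its result. At this aromatic carbon, in this pair, exchanging one halogen for the other therefore leaves the value within the scatter. No measurement at hand bears on this result.

Going by these compounds, whether an amine, a methoxy group or a carboxylic acid at this place would also stay within the scatter remains open. So does whether bromo in place of fluoro would read the same alongside the 3-(methylsulfanyl)phenyl group of compound 2.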